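The compounds below may be only part of what the source reports. "The series", "measured", "known", "first", "only" and "open" are said of these compounds alone.

Three compounds share one core and differ only in the group on the amine nitrogen of the ring at the far end. Compound 1 `CCCn1c(=O)c2[nH]c(-c3ccc(S(=O)(=O)N4CCN(c5ccc(Cl)cc5)CC4)cc3)nc2n(CC)c1=O` carries a 4-chlorophenyl there; in an assay on CHO cells for displacement of a labelled ligand from adenosine receptor A1 (Homo sapiens), read by scintillation counting, with a stated time of 90 min, tested at 1 uM, in the presence of a further agent that is not named here (a higher number here means more inhibition at the concentration tested (going by the name of the read-out), a lower number less inhibition), compound 1 gives 24%. Compound 2 `CCCn1c(=O)[nH]c2nc(-c3ccc(S(=O)(=O)N4CCN(Cc5ccc(Br)cc5)CC4)cc3)[nH]c2c1=O` carries a 4-bromobenzyl, and compound 2 gives 31%. Compound 3 `CCCn1c(=O)[nH]c2nc(-c3ccc(S(=O)(=O)N4CCN(c5ccccc5Br)CC4)cc3)[nH]c2c1=O` carries a 2-bromophenyl, and compound 3 gives 28%. For the measured compounds named here, the one measured step, a number 3 percentage points lower from compound 2 to compound 3 (within the scatter), is within the scatter, and compound 3 stands second highest of the three numbers, with compound 2 within the scatter on one side and compound 1 within the scatter on the other.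

Compound 4 `CCCn1c(=O)[nH]c2nc(-c3ccc(S(=O)(=O)N4CCN(c5ccccc5Cl)CC4)cc3)[nH]c2c1=O` is compound 3 with one change: chloro in place of bromo on an aromatic carbon. Going by the values given here, no measured step swaps one halogen for another; compounds 1 and 3 differ in both halogen and position, and their values sit within the scatter of each other. Among the compounds with values here, with no step pointing either way, the expected step of no change at the digits printed from compound 3 to compound 4 (within the scatter) is none beyond the scatter. Compound 4 is therefore estimated to give 28%, between 15% and 41%.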

Compound 4, a percentage reported as inhibition, at one concentration (the size of the read-out at that concentration, not a potency): 25%
For compound 4 the middle estimate is 3 percentage points above the measured one, within the range that was stated.
By their numbers in this assay, from the lowest: compounds 1, 4, 3 and 2 (each within the scatter of the next).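

In this assay the exchange of 2-bromophenyl for 2-chlorophenyl gives a number 3 percentage points lower from compound 3 to compound 4 (within the scatter) and so, in the only direct halogen swap shown, bromo and chloro cannot be told apart at this place on the aromatic ring. The 2-chlorophenyl group also cannot be told apart from the 4-bromobenzyl group on the amine nitrogen of the ring, since that exchange gives a number 6 percentage points lower from compound 2 to compound 4 (within the scatter) and a change of the whole group therefore shows no more than the change of one halogen. Nothing available explains why these groups read alike.

Going by these compounds, it remains open whether a group of another kind on that aromatic carbon, such as a methoxy, an amine or a carboxylic acid, would move the number beyond the scatter. Also open, on these data alone, is what a plain phenyl without any halogen would give, or a longer alkyl chain on the amine nitrogen.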